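The source may report more compounds than this note shows. Statements on the series, on what has been measured and on what is new or still open speak of the compounds shown alone.

Compound 1 `O=S(=O)(NCCCNCc1ccc(C(F)(F)F)cc1)c1cc(C(F)(F)F)cc(C(F)(F)F)c1` gives in a functional assay on BE(2)-C cells (Homo sapiens) for inhibition, read by MTT assay, with a stated time of 72 h (on this read-out higher numbers stand for weaker inhibition of growth and lower numbers for stronger inhibition of growth), a value of 2700 nM. Compound 2 `O=S(=O)(NCCCNCc1ccc(Br)cc1)c1cc(C(F)(F)F)cc(C(F)(F)F)c1`, which carries bromo in place of trifluoromethyl on an aromatic carbon, gives in this assay a value of 2700 nM, so the step of no change at the digits printed from compound 1 to compound 2 (within the scatter) shows no change within the scatter, and compound 2 stands level with compound 1 on the numbers at hand. Compound 3 `COc1cccc(CNCCCNS(=O)(=O)c2cc(C(F)(F)F)cc(C(F)(F)F)c2)c1` is not yet measured; it differs from compound 2 by 3-methoxyphenyl in place of 4-bromophenyl on a saturated chain carbon bound to an amine nitrogen. Among the compounds with values here, the only measured step that bears on this change is no change at the digits printed from compound 1 to compound 2 (within the scatter), in which a substituent on the same aromatic ring was exchanged and the value did not move beyond the scatter. Within the data shown here, that single step is the sole guide here, and it suggests that an exchange of this kind leaves the number roughly where it is. The step of no change at the digits printed from compound 2 to compound 3 (within the scatter) is therefore expected to be none beyond the scatter. Compound 3 is estimated at 2700 nM, with a range from 1000 nM to 7500 nM.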

Compound 3, concentration for 50% growth inhibition: 4500 nM
For compound 3 the middle estimate is 1.7-fold (0.22 log units) below the measured one, and the stated range covers the measured number.
By their numbers in this assay, from the lowest: compounds 1, 2 and 3 (each within the scatter of the next).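

The exchange at this saturated chain carbon bound to an amine nitrogen now goes beyond a swap of one 4-substituent for another. In this assay, 3-methoxyphenyl in place of 4-bromophenyl gives a 1.7-fold higher number from compound 2 to compound 3 (0.22 log units; within the scatter), and 3-methoxyphenyl in place of 4-(trifluoromethyl)phenyl gives a 1.7-fold higher number from compound 1 to compound 3 (0.22 log units; within the scatter), so a group with a hydrogen-bond acceptor and a different substitution place on the ring still stays within the scatter of both earlier compounds. Nothing at hand offers an explanation for this reading.

Since the substituent and its place on the ring differ together, the compounds shown cannot separate the two, and 4-methoxyphenyl would be needed to do so. They also leave open how a pyridine ring at this carbon, or a longer chain in the core, would read.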